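This account rests on a few compounds, and the source may have more. Where it says the series, first, only, none or still open, it means among the compounds named here.

Compound 3 `COc1cc(COc2cc(N)c(Cl)cc2C(=O)CCCCN2CCC(CNS(C)(=O)=O)CC2)cc(OC)c1` stands highest of the three measured compounds in a functional assay for antagonist activity at 5-hydroxytryptamine receptor 4 (Rattus norvegicus) (on this read-out lower numbers stand for lower potency and higher numbers for higher potency (the scale is a negative logarithm)), with 8.9. Compound 2 `COc1cc(COc2cc(N)c(Cl)cc2C(=O)CCCCN2CCC(NS(C)(=O)=O)CC2)cc(OC)c1` gives 8.4, and compound 1 `CCCC1CCN(CCCCC(=O)c2cc(Cl)c(N)cc2OCc2cc(OC)cc(OC)c2)CC1` gives 7.7. Compound 4 `COc1cc(COc2cc(N)c(Cl)cc2C(=O)CCCCN2CCC(CCNS(C)(=O)=O)CC2)cc(OC)c1` differs from compound 3 by (methanesulfonamido)methyl in place of methanesulfonamido on a saturated chain carbon bound to a saturated ring carbon. Going by the values given here, the one measured step that bears directly on this change is a number 0.50 log units higher from compound 2 to compound 3 (beyond the scatter), the same lengthening made on a saturated ring carbon rather than on the chain carbon. The steps of a number 0.70 log units higher from compound 1 to compound 2 (beyond the scatter) and a number 1.20 log units higher from compound 1 to compound 3 (beyond the scatter) show that introducing the methanesulfonamido group itself brought most of the gain. Among the compounds with values here, a second lengthening has no precedent here, so only a small step is estimated: a number 0.10 log units higher from compound 3 to compound 4 (within the scatter). Compound 4 is therefore expected to give 9, with a range from 8.4 to 9.6.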

Compound 4, negative logarithm of the antagonist equilibrium constant: 8.1
For compound 4 the middle estimate is 0.90 log units above the measured one, and the stated range ends above it.
By their numbers in this assay, from the lowest: compound 1; then compounds 4 and 2 (each within the scatter of the next); then compound 3.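

In this assay, the gain seen on lengthening the methanesulfonamido side chain once does not continue, since the next lengthening, to 2-(methanesulfonamido)ethyl, gives a number 0.80 log units lower from compound 3 to compound 4 (beyond the scatter). The longer chain also gives back the earlier gain, with a number 0.30 log units lower from compound 2 to compound 4 (within the scatter). Some advantage over the propyl group remains, at a number 0.40 log units higher from compound 1 to compound 4 (beyond the scatter).

No evidence here accounts for this reversal. On these data alone, whether a 3-(methanesulfonamido)propyl chain would lower the number further, or whether an amide or a carboxylic acid on the same chain would follow the sulfonamide series, remains open.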